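The compounds below may be only part of what the source reports. "The series", "measured", "known", "first", "only" and "open" are said of these compounds alone.

Measured so far:
Compound 1, `COc1cc(Cl)ccc1S(=O)(=O)Nc1cccnc1`: 4170 nM
Compound 2, `COc1ccc(C#N)cc1S(=O)(=O)Nc1cnc2ccccc2c1`: 38 nM
Compound 3, `COc1ccc(Cl)cc1S(=O)(=O)Nc1cncc(-c2cccnc2)c1`: 73 nM

All three were tested in an assay on isolated protein for inhibition of alkaline phosphatase, tissue-nonspecific isozyme (Homo sapiens); a lower number here means a stronger inhibitor, a higher number a weaker inhibitor. Compound 2 shows the lowest number of the three, but compound 3 lies within the usual scatter of it, so the two cannot be told apart; compound 1 is far off, well beyond the scatter.

Compound 4, `COc1ccc(Cl)cc1S(=O)(=O)Nc1cnc2ccccc2c1`, has not yet been measured in this assay. It differs from compound 2 in a single spot: chloro in place of cyano on an aromatic carbon. Among the measured compounds shown here, no measured pair shows this exact change, so the expected step from compound 2 is modest. The step of a 1.8-fold higher number from compound 2 to compound 4 (0.27 log units; within the scatter) is expected to stay close to the scatter, leaning toward a weaker inhibitor. Compound 4 is estimated at 70 nM, with a range of 25 nM to 200 nM.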

Compound 4, half-maximal inhibitory concentration: 6 nM
For compound 4 the middle estimate is 12-fold (1.07 log units) above the measured one; measured number below the stated range.
By their numbers in this assay, from the lowest: compound 4; then compounds 2 and 3 (each within the scatter of the next); then compound 1.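

In this assay, among the compounds shown here, the change at this aromatic carbon, para to a methoxy group, gives a 6.3-fold lower number from compound 2 to compound 4 (0.80 log units; beyond the scatter), the first direct reading of this position. The position therefore responds to what it carries, and of the two groups compared here on this core, chloro gives the lower number. No available evidence accounts for the gain. Still open, from the compounds shown here alone, is how an amine, a methyl or a carboxylic acid on this carbon would compare, and whether cyano in place of chloro on compound 3 would bring a similar loss.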